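The source may report more compounds than this note shows. Statements on the series, on what has been measured and on what is new or still open speak of the compounds shown alone.

Measured in a functional assay on HT-29 cells (Homo sapiens) for cytotoxicity, read by MTT assay, with a stated time of 96 h; on this read-out higher numbers stand for weaker inhibition and lower numbers for stronger inhibition:
compound 1 `COc1cc2c(cc1O)[C@@H]1CCc3cc(OC)c(OC)c(OC)c3[C@H]2CN1S(C)(=O)=O` gives 11600 nM
compound 2 `COc1cc2c(cc1O)[C@@H]1CCc3cc(OC)c(OC)c(OC)c3[C@H]2CN1C(C)=O` gives > 50000 nM, a limit

Compound 2 has only a limit in this assay and no number, as recorded in the limit of > 50000 nM in this assay, at which 1 of the 2 values shown sits. Compound 3 `COc1cc2c(cc1O)[C@@H]1CCc3cc(OC)c(OC)c(OC)c3[C@H]2CN1C(=O)C(F)(F)F` has trifluoromethyl in place of methyl on a carbonyl carbon, (trifluoromethyl in place of methyl on a carbonyl carbon), and is otherwise the same as compound 2. For the measured compounds named here, no measured step covers this exchange. The nearest is an at least 4.3-fold higher number from compound 1 to compound 2 (0.63 log units; beyond the scatter), a different change on the amine nitrogen in the ring. Compound 1 gives 11600 nM, so a number within the assay's range is known for the shared core. A modest move to a lower number is therefore expected, though a result at the limit remains quite possible. The expected change is an at least 1.4-fold lower number from compound 2 to compound 3 (0.15 log units; that floor lies within the scatter). Compound 3 is estimated at 35000 nM, within an expected range of 10000 nM to 100000 nM.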

Compound 3, half-maximal inhibitory concentration: 27800 nM
Estimate against measurement, compound 3: 1.3-fold (0.10 log units) above, within the range that was stated.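

In this assay, compound 3 gives 27800 nM, so a carbonyl group on this amine nitrogen in a ring can give a number inside the assay's range. Compound 2 carries only a limit, not a number: the limit of > 50000 nM in this assay, at which 1 of the 3 values shown sits. Trifluoromethyl in place of methyl on a carbonyl carbon gives an at least 1.7-fold lower number from compound 2 to compound 3 (0.25 log units; that floor lies within the scatter), while (trifluoromethyl)carbonyl in place of methylsulfonyl on the amine nitrogen gives a 2.4-fold higher number from compound 1 to compound 3 (0.38 log units; beyond the scatter), so methylsulfonyl keeps the lower number of the two groups with readable values.

Going by these compounds, the full size of the methyl to trifluoromethyl step remains open, as one end of it is a limit. Also open, on these data alone, is how this nitrogen behaves with a free amine, a simple ethyl group or a longer acyl chain, and whether trifluoromethyl on the sulfonyl group would shift the number of compound 1 as well.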